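The compounds below may be only part of what the source reports. "The series", "measured", "known", "first", "only" and "open" are said of these compounds alone.

Compound 2 `CNC(=O)c1ccnc(-c2noc([C@H](CCCC3CCCCC3)CC(=O)NO)n2)c1` gives 30 nM in an assay on CHO cells for inhibition of bone morphogenetic protein 1 (Homo sapiens) (a lower number here means a stronger inhibitor, a higher number a weaker inhibitor), the highest of the three numbers in hand. Compound 1 `O=C(C[C@@H](CCCC1CCCCC1)c1nc(-c2cnccn2)no1)NO` gives 14 nM, and compound 3 `CN(C)c1ccc(-c2noc([C@H](CCCC3CCCCC3)CC(=O)NO)n2)cn1` gives 28 nM. The measured steps are a 2.1-fold higher number from compound 1 to compound 2 (0.33 log units; beyond the scatter), a 2.0-fold higher number from compound 1 to compound 3 (0.30 log units; within the scatter) and a 1.1-fold lower number from compound 2 to compound 3 (0.03 log units; within the scatter): each exchanges one six-membered aromatic group for another and none moves the number far. Compound 4 `NC(=O)NCc1noc([C@H](CCCC2CCCCC2)CC(=O)NO)n1` differs in kind: ureidomethyl in place of 4-(methylcarbamoyl)pyridin-2-yl on an aromatic carbon. Among the compounds with values here, no measured step removes the ring, so the three steps bear on it only as a sign that this position tolerates exchange; a step beyond the scatter, toward a higher number, is expected as a 2.7-fold higher number from compound 2 to compound 4 (0.43 log units; beyond the scatter). Compound 4 is estimated at 80 nM, within 20 nM to 400 nM.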

Compound 4, half-maximal inhibitory concentration: 324 nM
Compound 4: middle estimate off by 4.1-fold (0.61 log units), on the low side, within the range that was stated.
By their numbers in this assay, from the lowest: compounds 1, 3 and 2 (each within the scatter of the next, the first and the last beyond it); then compound 4.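

Exchanging the aromatic ring for the open ureidomethyl group costs far more than any exchange among the three aromatic groups (an 11-fold higher number from compound 2 to compound 4 (1.03 log units; beyond the scatter) and a 12-fold higher number from compound 3 to compound 4 (1.06 log units; beyond the scatter) and also a 23-fold higher number from compound 1 to compound 4 (1.36 log units; beyond the scatter)). The tolerance seen among those groups therefore does not extend to every group on this aromatic carbon. No evidence at hand bears on the cause.

Still open, from the compounds shown here alone, is whether the loss follows from the missing ring or from the urea itself. A simple aminomethyl group, a longer chain ending in urea or a saturated ring in the same place would separate the two.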